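From an Ethyl to a 4-Fluorophenyl on an Aromatic Nitrogen

This account rests on a few compounds, and the source may have more. Where it says the series, first, only, none or still open, it means among the compounds named here.

Compound 1, `CCn1ccnc1-c1cc(OC)c(OC)c(OC)c1`: > 100000 nM
Compound 2, `COc1cc(-c2nccn2-c2ccc3[nH]ccc3c2)cc(OC)c1OC`: 4400 nM
Compound 3, `COc1cc(OC)cc(-n2ccnc2-c2cc(OC)c(OC)c(OC)c2)c1`: 41400 nM

The three compounds were tested in a functional assay on HeLa cells (Homo sapiens) for antiproliferative activity, read by MTT assay, with a stated time of 72 h; on this read-out higher numbers stand for weaker inhibition and lower numbers for stronger inhibition. Compound 1 returned only a limit, > 100000 nM, and so no number is known for it. Compound 1 therefore stands at the limit of > 100000 nM in this assay, at which 1 of the 3 values shown sits. Compound 2 gave 4400 nM in this assay, and compound 3 gave 41400 nM, both as measured numbers.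

Compound 4, `COc1cc(-c2nccn2-c2ccc(F)cc2)cc(OC)c1OC`, is not yet measured in this assay. It differs from compound 1 in one place: 4-fluorophenyl in place of ethyl on an aromatic nitrogen. Compound 2 and compound 3 each carry an aromatic group on that nitrogen and both give measured numbers, whereas compound 1 with its ethyl does not. The expected step from compound 1 to compound 4 is therefore a move toward stronger inhibition, estimated as an at least 8.3-fold lower number from compound 1 to compound 4 (0.92 log units; beyond the scatter), beyond the scatter. For compound 4 the estimated value in this assay is 12000 nM, expected to lie between 2500 nM and 60000 nM.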

Compound 4, half-maximal inhibitory concentration: 17500 nM
Compound 4: middle estimate off by 1.5-fold (0.16 log units), on the low side; the measured number falls inside the stated range.
By their numbers in this assay, from the lowest: compound 2; then compound 4; then compound 3. At a limit, above all of these: compound 1.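

In this assay, replacing the ethyl on the aromatic nitrogen with 4-fluorophenyl gives a measured number, with an at least 5.7-fold lower number from compound 1 to compound 4 (0.75 log units; beyond the scatter). A measured number at this position therefore does not require the particular aromatic groups of compound 2 and compound 3: compound 4 gives 17500 nM, which falls between compound 2 at 4400 nM and compound 3 at 41400 nM. Compound 1 holds only a limit, so the step from it is a bound and not a measured size: the limit of > 100000 nM in this assay, at which 1 of the 4 values shown sits.

The compounds shown leave open what the fluorine contributes, which an unsubstituted phenyl on the same nitrogen would address. They also leave open whether an aromatic ring directly on this nitrogen is needed at all, which a benzyl group or a longer chain such as butyl would test.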